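The source may report more compounds than this note shows. Statements on the series, on what has been measured and on what is new or still open speak of the compounds shown alone.

Measured so far in a functional assay on Flp-In T-REx293 cells for antagonist activity at Free fatty acid receptor 1 (Homo sapiens), read by calcium flux; on this read-out higher numbers stand for weaker inhibition and lower numbers for stronger inhibition: Compound 1 `O=S1(=O)c2ccccc2CN1c1cc(F)cc(Oc2cccnc2)c1` reaches only a limit of the assay, > 100000 nM. Compound 2 `O=S1(=O)c2ccccc2CN1c1cccc(Oc2ccccc2)c1` gives 174 nM. Compound 3 `Cc1ccccc1Oc1cc(F)cc(N2Cc3ccccc3S2(=O)=O)c1` gives 44700 nM.

Compound 3 stands highest of the two numbers given; compound 2 lies well below it. Among the measured compounds shown here, the only measured step at the same place, an at least 2.2-fold lower number from compound 1 to compound 3 (0.34 log units; beyond the scatter), starts from a limit of > 100000 nM in this assay, at which 1 of the 3 values shown sits, and so fixes only a floor on its size. Compound 4 `Cc1ccc(Oc2cc(F)cc(N3Cc4ccccc4S3(=O)=O)c2)cc1` differs from compound 3 by 4-methylphenyl in place of 2-methylphenyl on an oxygen on an aromatic ring. For the measured compounds named here, no measured step moves a methyl group around a phenoxy ring, so the direction remains open; a step of modest size either way is expected, a 2.2-fold lower number from compound 3 to compound 4 (0.35 log units; beyond the scatter). Compound 4 is therefore estimated at 20000 nM in this assay, with a range from 3000 nM to 100000 nM.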

Compound 4, half-maximal inhibitory concentration: 2880 nM
Compound 4: middle estimate off by 6.9-fold (0.84 log units), on the high side, and the stated range ends above it.
By their numbers in this assay, from the lowest: compound 2; then compound 4; then compound 3. At a limit, above all of these: compound 1.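

In this assay, the same atoms joined differently give a large change: moving the methyl group from 2-methylphenyl to 4-methylphenyl on the oxygen shifts the number substantially (a 16-fold lower number from compound 3 to compound 4 (1.19 log units; beyond the scatter)). Unlike the earlier step at this place, this one is read between two numbers and so has a real size. The change from pyridin-3-yl to 4-methylphenyl is a floor only (an at least 34-fold lower number from compound 1 to compound 4 (1.54 log units; beyond the scatter)), its starting point being a limit and not a number.

On these data alone, what an ethyl group, a methoxy group or a chlorine would do on the same ring remains open.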